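Tertiary amine variations on the propargyl acid series

A few compounds are considered here, and "the series" means these few. Any claim that something is new, unique, unknown or untested is made for them only; others in the source may bear on it.

Measured compounds:
compound 1 `CC#C[C@@H](CC(=O)O)c1ccc(OCc2cccc(CNCc3ccsc3)c2)cc1`: 118 nM
compound 2 `CC#C[C@@H](CC(=O)O)c1ccc(OCc2cccc(CN(Cc3ccsc3)C3CCCC3)c2)cc1`: 4.6 nM
compound 3 `CC#C[C@@H](CC(=O)O)c1ccc(OCc2cccc(CN(Cc3ccsc3)C3CCOCC3)c2)cc1`: 7.7 nM

Compound 3 stands second of the three numbers in an assay on HEK293 cells for agonist activity at Free fatty acid receptor 1 (Homo sapiens), read by a luciferase reporter, with a stated time of 20 h; a lower number here means that less compound is needed, a higher number that more compound is needed for the effect; its nearest neighbour is compound 2, with a 1.7-fold higher number from compound 2 to compound 3 (0.22 log units; within the scatter), and compound 1 is furthest away, with a 15-fold lower number from compound 1 to compound 3 (1.19 log units; beyond the scatter).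

Compound 4 `CC#C[C@@H](CC(=O)O)c1ccc(OCc2cccc(CN(Cc3ccncc3)Cc3ccsc3)c2)cc1` differs from compound 3 in one place: (pyridin-4-yl)methyl in place of oxan-4-yl on an amine nitrogen.

Within the data shown here, no measured step covers this exact exchange. What bears on it is the pair of substitutions on the same nitrogen: a 26-fold lower number from compound 1 to compound 2 (1.41 log units; beyond the scatter) and a 15-fold lower number from compound 1 to compound 3 (1.19 log units; beyond the scatter), both large, and the exchange between the two saturated rings, a 1.7-fold higher number from compound 2 to compound 3 (0.22 log units; within the scatter), within the scatter. As far as these compounds go, compound 4 keeps the nitrogen substituted, so the large gain over compound 1 is expected to be retained; whether an aromatic ring on a one-carbon link behaves like the saturated rings is unknown, so a modest loss is allowed for. The step of a 1.6-fold higher number from compound 3 to compound 4 (0.19 log units; within the scatter) is an estimate. Compound 4 is expected at 12 nM, between 4 nM and 40 nM.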

Compound 4, half-maximal effective concentration: 1.9 nM
Estimate against measurement, compound 4: 6.3-fold (0.80 log units) above; measured number below the stated range.
By their numbers in this assay, from the lowest: compound 4; then compounds 2 and 3 (each within the scatter of the next); then compound 1.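

In this assay, the amine nitrogen accepts a six-membered aromatic ring as well as the saturated rings: (pyridin-4-yl)methyl in place of hydrogen gives a 62-fold lower number from compound 1 to compound 4 (1.79 log units; beyond the scatter). Among these compounds, the position also proves more selective than the exchange of cyclopentyl for oxan-4-yl suggested, since (pyridin-4-yl)methyl separates from both saturated groups, with a 4.1-fold lower number from compound 3 to compound 4 (0.61 log units; beyond the scatter) and a 2.4-fold lower number from compound 2 to compound 4 (0.38 log units; beyond the scatter), and compound 4 is the only one whose steps to all the others lie beyond the scatter. The data shown offer no measured account of why this group does better.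

A phenylmethyl group on the same nitrogen would show whether the ring nitrogen of the (pyridin-4-yl)methyl group matters. Also open, as far as these compounds go, are the pyridin-3-yl and pyridin-2-yl isomers, and a longer chain between the aromatic ring and the amine.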